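Cyclopropyl ester after the difluorocyclohexyl ester: working notes

The compounds below may be only part of what the source reports. "The series", "measured", "known", "first", "only" and "open" are said of these compounds alone.

Compound 1 `C=C1C(=O)O[C@H]2CC3=C[C@H](C/C(C)=C/[C@@H](OC(=O)c4ccc(C(C)=O)cc4)[C@H]12)OC3=O`: 2200 nM
Compound 2 `C=C1C(=O)O[C@H]2CC3=C[C@H](C/C(C)=C/[C@@H](OC(=O)CCCCBr)[C@H]12)OC3=O`: > 10000 nM (a limit of the assay)
Compound 3 `C=C1C(=O)O[C@H]2CC3=C[C@H](C/C(C)=C/[C@@H](OC(=O)C4CCC(F)(F)CC4)[C@H]12)OC3=O`: > 10000 nM (a limit of the assay)

Compound 3 stands at > 10000 nM in a functional assay on NCI-H460 cells (Homo sapiens) for cytotoxicity, read by MTT assay, with a stated time of 48 h (a higher number here means a weaker inhibitor, a lower number a stronger inhibitor), and this is a limit, not a number. Among the compounds with values here, the series so far shows the limit of > 10000 nM in this assay, at which 2 of the 3 values shown sit, for these compounds.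

The next structure is compound 4 `C=C1C(=O)O[C@H]2CC3=C[C@H](C/C(C)=C/[C@@H](OC(=O)C4CC4)[C@H]12)OC3=O` and the change is cyclopropyl in place of 4,4-difluorocyclohexyl on a carbonyl carbon with cyclopropyl in place of 4,4-difluorocyclohexyl on a carbonyl carbon.

Three measured steps at this same place bear on it. The step of an at least 4.5-fold higher number from compound 1 to compound 2 (0.65 log units; beyond the scatter) and the step of an at least 4.5-fold higher number from compound 1 to compound 3 (0.65 log units; beyond the scatter) both lie beyond the scatter and both lead away from 4-acetylphenyl. The step that the two limits leave unreadable from compound 2 to compound 3 gives no size at all. Cyclopropyl, like 4-bromobutyl in compound 2 and 4,4-difluorocyclohexyl in compound 3, is not the 4-acetylphenyl group of compound 1, so no clear gain is expected in this assay and compound 4 is expected to stay close to the limit.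

The expected change is a number no higher from compound 3 to compound 4 (the limit leaves the size open) and no step beyond the scatter can be forecast with confidence.

For compound 4 the estimated value is 10000 nM with an expected range from 4000 nM to 25000 nM in this assay once measured.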

Compound 4, half-maximal inhibitory concentration: 3000 nM
Estimate against measurement, compound 4: 3.3-fold (0.52 log units) above, outside the stated range (below it).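

In this assay, within the data shown here, the earlier compounds could be read as showing a loss whenever 4-acetylphenyl left the carbonyl carbon, but cyclopropyl does not fit that reading, with a 1.4-fold higher number from compound 1 to compound 4 (0.13 log units; within the scatter). Among the three non-aromatic groups the position is not indifferent, as cyclopropyl gives an at least 3.3-fold lower number from compound 3 to compound 4 (0.52 log units; beyond the scatter) and an at least 3.3-fold lower number from compound 2 to compound 4 (0.52 log units; beyond the scatter), so within these four compounds a measurable value does not depend on an aromatic ring at this place. Compounds 2 and 3 carry limits of the assay rather than numbers, so these two steps fix only a smallest size and the step between compounds 2 and 3 cannot be read: the limit of > 10000 nM in this assay, at which 2 of the 4 values shown sit.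

A plain cyclohexyl ester or a cyclobutyl ester would be needed to tell whether the gap between compound 3 and compound 4 follows ring size or the two fluorines of 4,4-difluorocyclohexyl. Also open, from the compounds shown here alone, is how this position takes a group carrying an amine or a carboxylic acid, and whether a short open chain such as ethyl behaves like cyclopropyl or like the 4-bromobutyl of compound 2.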